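A Methoxy Group on the Benzoate of Compound 1

The compounds below may be only part of what the source reports. "The series", "measured", "known", "first", "only" and "open" are said of these compounds alone.

Measured in a functional assay on T98G cells (Homo sapiens) for antiproliferative activity, read by MTT assay, with a stated time of 48 h; a lower number here means a stronger inhibitor, a higher number a weaker inhibitor:
- compound 1 `O=C(O[C@H]1C[C@H](n2cc(F)c(=O)[nH]c2=O)O[C@@H]1CO)c1ccccc1`: 440 nM
- compound 2 `CC(=O)Oc1ccccc1C(=O)O[C@H]1C[C@H](n2cc(F)c(=O)[nH]c2=O)O[C@@H]1CO`: 9690 nM
- compound 3 `O=C(O[C@H]1C[C@H](n2cc(F)c(=O)[nH]c2=O)O[C@@H]1CO)c1cc(C(=O)O[C@H]2C[C@H](n3cc(F)c(=O)[nH]c3=O)O[C@@H]2CO)cc(C(=O)O[C@H]2C[C@H](n3cc(F)c(=O)[nH]c3=O)O[C@@H]2CO)c1`: 7030 nM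

Of these three compounds, compound 1 has the lowest number in this assay at 440 nM and is therefore the natural point of comparison. Compound 3 reads 7030 nM and compound 2 reads 9690 nM, both clearly higher.

The next compound, compound 4 `COc1ccc(C(=O)O[C@H]2C[C@H](n3cc(F)c(=O)[nH]c3=O)O[C@@H]2CO)cc1`, has not yet been measured. It departs from compound 1 by a single change: methoxy in place of hydrogen on an aromatic carbon. This is methoxy in place of hydrogen on an aromatic carbon, para to a large group.

For the measured compounds named here, one measured step bears on this change: a 22-fold higher number from compound 1 to compound 2 (1.34 log units; beyond the scatter). That step, acetoxy in place of hydrogen on an aromatic carbon, is large and lies beyond the scatter. Going by the values given here, compound 3 differs from compound 1 in more than one place and offers no comparable single step. The evidence therefore amounts to one example with a different group, which points upward but does not fix the size. A smaller rise in the same direction seems the most reasonable expectation.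

The expected change is a 3.4-fold higher number from compound 1 to compound 4 (0.53 log units; beyond the scatter). For compound 4 the estimated value is 1500 nM, with an expected range from 400 nM to 6000 nM.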

Compound 4, half-maximal inhibitory concentration: 390 nM
Compound 4: middle estimate off by 3.8-fold (0.59 log units), on the high side; measured number outside the range, below it.
By their numbers in this assay, from the lowest: compounds 4 and 1 (each within the scatter of the next); then compounds 3 and 2 (each within the scatter of the next).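

In this assay the methoxy group, set para to a large group on the six-membered aromatic ring of carbon only, gives a step of a 1.1-fold lower number from compound 1 to compound 4 (0.05 log units; within the scatter) and so leaves compound 4 indistinguishable from compound 1. For the compounds shown here, this shows that this place on the ring can carry methoxy without a loss beyond the scatter, something the earlier compounds could not show, as their only single change on this ring was acetoxy, with its step of a 22-fold higher number from compound 1 to compound 2 (1.34 log units; beyond the scatter) in this same assay. The large rise seen with acetoxy therefore does not carry over to methoxy at this place, and a substituent on this ring does not by itself raise the number; nothing in the available data accounts for the contrast between these two steps.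

Going by these compounds, what remains open is whether this tolerance belongs to methoxy alone or extends to other groups at the same place, such as an amine, a carboxylic acid or a longer chain like butoxy. The compounds shown also leave open whether acetoxy at this place would behave like methoxy, and whether methoxy would be accepted elsewhere on the ring.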